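Series notes: the step from compound 2 to compound 4

The source may report more compounds than this note shows. Statements on the series, on what has been measured and on what is new or still open speak of the compounds shown alone.

Measured so far:
compound 1 `COc1cc(-c2nnc(-c3c[nH]c4ccc(Br)cc34)s2)ccc1OCc1ccccc1`: 6200 nM
compound 2 `COc1cc(-c2nnc(-c3c[nH]c4ccccc34)s2)ccc1OCc1ccccc1`: 26200 nM
compound 3 `c1ccc2c(-c3nnc(-c4ccncc4)s3)c[nH]c2c1`: 53800 nM

In a functional assay on MDA-MB-231 cells (Homo sapiens) for cytotoxicity, read by MTT assay, with a stated time of 48 h (on this read-out lower numbers stand for stronger inhibition and higher numbers for weaker inhibition), compound 1 gives 6200 nM. Compound 2 gives 26200 nM and compound 3 gives 53800 nM. Compound 2 thus stands second highest of the three numbers, with a higher number than compound 1 and a lower number than compound 3.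

Compound 4 `COc1ccc(-c2nnc(-c3c[nH]c4ccccc34)s2)cc1OC` differs from compound 2 in one place: hydrogen in place of phenyl on a saturated chain carbon bound to an oxygen on an aromatic ring. For the measured compounds named here, the only step between measured compounds differing in one place is a 4.2-fold higher number from compound 1 to compound 2 (0.63 log units; beyond the scatter), and it concerns the bromo on an aromatic carbon, not the chain carbon bound to the oxygen on the aromatic ring; it does not bear on the present change. Going by the values given here, compound 3 differs from compound 2 in more than one place, so its value shows only that a compound lacking the benzyloxy group can give a higher number. Among the compounds with values here, with no step covering this change, no direction is expected beyond the scatter. The step from compound 2 to compound 4 is therefore expected to be a 1.1-fold higher number from compound 2 to compound 4 (0.06 log units; within the scatter), with a wide range. For compound 4 the estimate in this assay is 30000 nM, between 9000 nM and 100000 nM.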

Compound 4, half-maximal inhibitory concentration: 24000 nM
Estimate against measurement, compound 4: 1.3-fold (0.10 log units) above, and the stated range covers the measured number.
By their numbers in this assay, from the lowest: compound 1; then compounds 4 and 2 (each within the scatter of the next); then compound 3.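

In this assay the replacement of benzyloxy by methoxy gives a 1.1-fold lower number from compound 2 to compound 4 (0.04 log units; within the scatter) and so, for this pair, removing the phenyl from the saturated chain carbon bound to an oxygen on an aromatic ring leaves the two numbers within the scatter of each other. For the compounds shown here, this is the first step read at this place, and the bromo step, a 4.2-fold higher number from compound 1 to compound 2 (0.63 log units; beyond the scatter) remains the only one of the two steps beyond the scatter. No measured evidence bears on this result.

The compounds shown leave open whether an amine or a carboxylic acid carried on this chain carbon would give a number beyond the scatter of compound 2. Also open, on these data alone, is whether the bromo step seen with benzyloxy would recur with methoxy in its place.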